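Swapping the amine on a kinase-inhibitor scaffold

This account rests on a few compounds, and the source may have more. Where it says the series, first, only, none or still open, it means among the compounds named here.

Among the measured compounds shown here, compound 1 `COc1cc2c(Oc3ccc(NC(=O)c4cc(-c5ccccc5)ccn4)cc3F)ccnc2cc1OCCCN1CCN(C)CC1` is one of two compounds measured in a functional assay on NCI-H460 cells (Homo sapiens) for cytotoxicity, read by MTT assay, with a stated time of 72 h (on this read-out higher numbers stand for weaker inhibition and lower numbers for stronger inhibition), where compound 1 gives 91 nM, the lowest of the two numbers. Its nearest neighbour is compound 2 `COc1cc2c(Oc3ccc(NC(=O)c4cc(-c5ccc(C(F)(F)F)cc5)ccn4)cc3F)ccnc2cc1OCCCN1CCN(C)CC1`, which in this assay gives 160 nM; the step of a 1.8-fold higher number from compound 1 to compound 2 (0.25 log units; within the scatter) stays within the scatter. Compound 3 `COc1cc2c(Oc3ccc(NC(=O)c4cc(-c5ccccc5)ccn4)cc3F)ccnc2cc1OCCCN1CCCC1` has not yet been measured. It differs from compound 1 by pyrrolidin-1-yl in place of 4-methylpiperazin-1-yl on a saturated chain carbon, three bonds along the chain from an oxygen on an aromatic ring. For the measured compounds named here, the only measured step, from compound 1 to compound 2, concerns the aromatic ring of the amide part and does not touch the chain amine, so nothing measured here bears directly on the change to compound 3. With no step beyond the scatter anywhere in the set, the size of the step in this assay to compound 3 is expected to be a 1.1-fold higher number from compound 1 to compound 3 (0.04 log units; within the scatter), that is, none beyond the scatter. Compound 3 is therefore estimated at 100 nM, with a range from 35 nM to 300 nM.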

Compound 3, half-maximal inhibitory concentration: 130 nM
Compound 3: middle estimate off by 1.3-fold (0.11 log units), on the low side; measured number inside the range.
By their numbers in this assay, from the lowest: compounds 1, 3 and 2 (each within the scatter of the next).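

Among the compounds shown here, this is the first reading at the chain amine, and in this assay pyrrolidin-1-yl in place of 4-methylpiperazin-1-yl on the 3-carbon-linked propyl chain gives a 1.4-fold higher number from compound 1 to compound 3 (0.15 log units; within the scatter). The end of the 3-(4-methylpiperazin-1-yl)propyl chain can therefore carry a five-membered non-aromatic ring with 1 hetero atom instead of a six-membered one with 2, with no change beyond the scatter in this cell read-out. No measurement offers an explanation for this result.

Going by these compounds, whether morpholin-4-yl or an open-chain dimethylamino group at the same place would also stay within the scatter remains open. So does the effect of a shorter or longer chain, and whether pyrrolidin-1-yl behaves the same way alongside the trifluoromethyl group of compound 2.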